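The compounds below may be only part of what the source reports. "The series", "measured", "known", "first", "only" and "open" are said of these compounds alone.

Working notes on a series of three compounds on a shared core. Compound 1 `C#CCSc1nnc(C)n1N1C(=O)c2ccccc2C1=O` and compound 2 `C=CCSc1nnc(CC)n1N1C(=O)c2ccccc2C1=O` have been measured in a functional assay on MKN-45 cells (Homo sapiens) for cytotoxicity, read by MTT assay, with a stated time of 48 h; a higher number here means a weaker inhibitor, a lower number a stronger inhibitor. In this assay compound 1 gives only a limit, > 200000 nM. In the same assay compound 2 likewise gives only a limit, > 200000 nM. Compound 2 thus stands at the limit of > 200000 nM in this assay, at which 2 of the 2 values shown sit, with no numbered value to set it against. Compound 3 `CCc1nnc(SC)n1N1C(=O)c2ccccc2C1=O` is not yet measured; it differs from compound 2 by hydrogen in place of vinyl on a saturated chain carbon bound to a sulfur. For the measured compounds named here, no measured step exists for comparison, so the expected step that the limit leaves unreadable from compound 2 to compound 3 is none beyond the scatter. Compound 3 is therefore expected at 250000 nM, between 120000 nM and 600000 nM, most likely again reported as a limit only.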

Compound 3, half-maximal inhibitory concentration: > 200000 nM
Compound 3: a limit, no number; the forecaster's own chance of this, stated with the estimate: 85%; the middle value lies beyond the limit too.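

No step can be read from compound 2 to compound 3, since both give only a limit: the limit of > 200000 nM in this assay, at which 3 of the 3 values shown sit.

The compounds shown leave open whether any change on the shared core would give a numbered value in this assay.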